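Series notes: aryl exchange on compound 2

A few compounds are considered here, and "the series" means these few. Any claim that something is new, unique, unknown or untested is made for them only; others in the source may bear on it.

Measured compounds:
- `Oc1cc(F)ccc1C(c1ccc2ccoc2c1O)N1CCCCC1` — compound 1, 1070 nM
- `Cc1ccnc(NC(c2ccc(C(F)(F)F)cc2)c2ccc3cccnc3c2O)c1` — compound 2, 26500 nM
- `Oc1c(C(c2ccc(F)cc2)N2CCCCC2)ccc2c1OCCO2` — compound 3, 290 nM

In an assay for inhibition of protein disulfide-isomerase (Homo sapiens), with a stated time of 1 h (a higher number here means a weaker inhibitor, a lower number a stronger inhibitor), compound 2 gives 26500 nM, the highest number of the three; compound 1 and compound 3 both sit lower by margins beyond the scatter, with compound 3 giving the lowest number. Compound 4 is `Cc1ccnc(NC(c2ccccc2C)c2ccc3cccnc3c2O)c1`, not yet measured in this assay. It differs from compound 2 by 2-methylphenyl in place of 4-(trifluoromethyl)phenyl on a saturated chain carbon bound to an aromatic carbon and a nitrogen on an aromatic ring. For the measured compounds named here, no measured pair shows this change, and compound 1 and compound 3 differ from compound 2 in the amine and the core as well, so they offer no direct guide. The step from compound 2 to compound 4 is therefore expected to be small, a 1.3-fold lower number from compound 2 to compound 4 (0.12 log units; within the scatter), with no clear direction beyond the scatter. Compound 4 is estimated at 20000 nM, in the range 6000 nM to 60000 nM.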

Compound 4, half-maximal inhibitory concentration: > 40000 nM
Compound 4: no number, only a limit; the forecaster's own chance of this, stated with the estimate: 20%; at least 2.0-fold (0.30 log units) between middle value and limit.
By their numbers in this assay, from the lowest: compound 3; then compound 1; then compound 2. At a limit, above all of these: compound 4.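

Compound 4 gives only a limit in this assay, not a number: the limit of > 40000 nM in this assay, at which 1 of the 4 values shown sits. 2-Methylphenyl in place of 4-(trifluoromethyl)phenyl on this saturated chain carbon gives an at least 1.5-fold higher number from compound 2 to compound 4 (0.17 log units; that floor lies within the scatter), so the change brings no lower number here, and the full size of the step cannot be read. This is the only direct reading at this position among the compounds shown.

The change alters both the substituent and its place on the ring, and the two effects remain unseparated. As far as these compounds go, whether 4-methylphenyl or unsubstituted phenyl would stay near compound 2 remains open.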